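Fluorobenzyl to chlorobenzyl: notes on growth inhibition

The source may report more compounds than this note shows. Statements on the series, on what has been measured and on what is new or still open speak of the compounds shown alone.

compound 1 `N#C/C(=C\c1ccccc1OS(=O)(=O)c1ccccc1[N+](=O)[O-])C(=O)Nc1nnc(Cc2ccc(F)cc2)s1`: 35%
compound 2 `N#C/C(=C\c1ccccc1OS(=O)(=O)c1ccccc1[N+](=O)[O-])C(=O)Nc1nnc(Cc2cccc(F)c2)s1`: 23%

Within the data shown here, in a functional assay on HL-60 cells (Homo sapiens) for inhibition, read by CCK-8 assay, with a stated time of 48 h, tested at 20 uM (a higher number here means more inhibition of growth at the concentration tested, a lower number less inhibition of growth), compound 2 gives 23%, the lower of the two numbers so far, and compound 1 gives 35%. The compound still to be measured is compound 3 `N#C/C(=C\c1ccccc1OS(=O)(=O)c1ccccc1[N+](=O)[O-])C(=O)Nc1nnc(Cc2ccc(Cl)cc2)s1`. Its difference from compound 2 is 4-chlorophenyl in place of 3-fluorophenyl on a saturated chain carbon bound to an aromatic carbon. In words, it has 4-chlorophenyl in place of 3-fluorophenyl on a saturated chain carbon bound to an aromatic carbon.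

Among the measured compounds shown here, one measured step bears on this change: a number 12 percentage points lower from compound 1 to compound 2 (beyond the scatter). That step is modest and came with 3-fluorophenyl in place of 4-fluorophenyl at the same place. For the measured compounds named here, the change to compound 3 also leaves 3-fluorophenyl, but what enters is 4-chlorophenyl rather than 4-fluorophenyl, and no measured step covers that exchange. The measured step, read in reverse, is therefore only a rough guide, and a modest rise in this assay is expected. The expected size is a number 11 percentage points higher from compound 2 to compound 3 (beyond the scatter). For compound 3 the estimate is 34%, with an expected range of 20% to 50%.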

Compound 3, percent growth inhibition at one concentration: 19%
Compound 3: middle estimate off by 15 percentage points, on the high side; the whole stated range lies above it.
By their numbers in this assay, from the lowest: compounds 3 and 2 (each within the scatter of the next); then compound 1.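

In this assay, 4-chlorophenyl in place of 3-fluorophenyl on a saturated chain carbon bound to an aromatic carbon gives a number 4 percentage points lower from compound 2 to compound 3 (within the scatter), so this exchange does not separate compound 2 and compound 3. Compound 1 and compound 3 differ only in the halogen, and chloro in place of fluoro on an aromatic carbon gives a number 16 percentage points lower from compound 1 to compound 3 (beyond the scatter); with a number 12 percentage points lower from compound 1 to compound 2 (beyond the scatter), this leaves compound 1 as the only one of the three set apart beyond the scatter, and shows that keeping the 4-substituted phenyl pattern does not by itself preserve its number. No measurement on hand accounts for this difference between the fluoro and chloro compounds.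

The compounds shown leave open whether the number of compound 1 is particular to 4-fluorophenyl or would also be reached by an unsubstituted phenyl, a 4-methoxyphenyl or a 4-methylphenyl at the same place. Also open, on these data alone, is whether a longer chain between the aryl ring and the shared core would alter the picture in this assay.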